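Solubility of compound 4: cyclobutylmethoxy for cyclopentylamino

A few compounds are considered here, and "the series" means these few. Any claim that something is new, unique, unknown or untested is made for them only; others in the source may bear on it.

The series holds a single number in a physicochemical assay for solubility; a lower number here means a less soluble compound, a higher number a more soluble compound. There compound 2 `CS(=O)(=O)c1ccc(-n2nc(C(F)(F)F)cc2NC2CCCC2)nc1` gives 25 ug/mL. Compound 1 `CS(=O)(=O)c1ccc(-n2nc(C(F)(F)F)cc2NC2CCC2)nc1` carries the entry "not determined" (no result reported), and compound 3 `CS(=O)(=O)c1ccc(-n2nc(C(F)(F)F)c(C#N)c2NC2CCCC2)nc1` carries the entry "not determined" (no result reported). For the measured compounds named here, compound 2 therefore stands alone, with no other measured compound to rank it against.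

Compound 4 `CS(=O)(=O)c1ccc(-n2nc(C(F)(F)F)cc2OCC2CCC2)nc1` has yet to be measured. It carries cyclobutylmethoxy in place of cyclopentylamino on an aromatic carbon. Going by the values given here, the series offers no step between measured compounds to serve as a guide. The expectation therefore rests only on this structural change and on compound 2 at 25 ug/mL. The estimated step of a 1.7-fold lower number from compound 2 to compound 4 (0.22 log units; within the scatter) is small and downward, and no change beyond the scatter is expected. In this assay the estimated value for compound 4 is 15 ug/mL, with an expected range from 4 ug/mL to 50 ug/mL.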

Compound 4, solubility: 100 ug/mL
Compound 4: the middle estimate sits 6.7-fold (0.82 log units) below what was measured; the measured number lies above the stated range.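

In this assay, the position on the aromatic carbon of the five-membered aromatic ring now has its first readable step: cyclobutylmethoxy in place of cyclopentylamino gives a 4.0-fold higher number from compound 2 to compound 4 (0.60 log units; beyond the scatter). This shows that the number at this position can move beyond the scatter when one six-heavy-atom group replaces another, although the exchange also takes the hydrogen-bond donor count from 1 to 0 and the ring from five-membered to four-membered. No measurement here accounts for the step.

The compounds shown do not separate the effect of the ring from that of the atom joining it to the core, and compound 1 and compound 3 carry no number to compare. Cyclopentyloxy or cyclobutylmethylamino at this position would pull those two parts of the change apart.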